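Predicting an ethoxycarbonyl analogue of an anilide dithiocarbamate

The source may report more compounds than this note shows. Statements on the series, on what has been measured and on what is new or still open speak of the compounds shown alone.

Measured compounds in a functional assay on MCF7 cells (Homo sapiens) for cytotoxicity, read by MTT assay, with a stated time of 72 h; a higher number here means a weaker inhibitor, a lower number a stronger inhibitor:
Compound 1 `O=C(CSC(=S)N[C@H]1CCOC1=O)Nc1ccccc1`: > 128000 nM (a limit, not a number).
Compound 2 `O=C(CSC(=S)N[C@H]1CCOC1=O)Nc1cccc(C(F)(F)F)c1`: 3130 nM.
Compound 3 `O=C(CSC(=S)N[C@H]1CCOC1=O)Nc1cccc([N+](=O)[O-])c1`: 5460 nM.

Going by these compounds, compound 1 stands at the assay limit (the limit of > 128000 nM in this assay, at which 1 of the 3 values shown sits), so its true potency is unknown beyond that boundary. Compound 4 `CCOC(=O)c1ccc(NC(=O)CSC(=S)N[C@H]2CCOC2=O)cc1` differs from compound 1 by ethoxycarbonyl in place of hydrogen on an aromatic carbon. The two measured steps from the same starting point are an at least 40-fold lower number from compound 1 to compound 2 (1.61 log units; beyond the scatter) and an at least 23-fold lower number from compound 1 to compound 3 (1.37 log units; beyond the scatter), both large lowering steps, while a 1.7-fold higher number from compound 2 to compound 3 (0.24 log units; within the scatter) shows the two substituted analogues sit together. A different group on the same ring may not behave alike, but the measured steps support expecting a large lowering step in this assay. The estimate for compound 4 is therefore 8000 nM, with a range of 1500 nM to 60000 nM, meaning an expected step of an at least 16-fold lower number from compound 1 to compound 4 (1.20 log units; beyond the scatter).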

Compound 4, half-maximal inhibitory concentration: 60300 nM
Compound 4: the middle estimate sits 7.5-fold (0.88 log units) below what was measured, outside the stated range (above it).
By their numbers in this assay, from the lowest: compounds 2 and 3 (each within the scatter of the next); then compound 4. At a limit, above all of these: compound 1.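

In this assay, placing ethoxycarbonyl on an aromatic carbon, para to a large group, gives an at least 2.1-fold lower number from compound 1 to compound 4 (0.32 log units; beyond the scatter). This shows that a group at this place, with no ring and a carbonyl, still lowers the number beyond the scatter. The true size of the step remains unknown because compound 1 stands at a limit: the limit of > 128000 nM in this assay, at which 1 of the 4 values shown sits.

The compounds shown do not separate the effect of the group from that of its place on the ring. Going by these compounds, how an amine, a carboxylic acid or a longer ester chain would behave at this place also remains open.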